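The source may report more compounds than this note shows. Statements on the series, on what has been measured and on what is new or still open speak of the compounds shown alone.

Compound 1 `Cc1cccc(C)c1Oc1ccc([N+](=O)[O-])c(Nc2ccc(C#N)cc2)c1` in an ADME assay on H9 cells (Homo sapiens) for cytotoxicity, read by XTT assay, with a stated time of 6 days (on this read-out lower numbers stand for higher toxicity in this test and higher numbers for lower toxicity in this test), gives 69600 nM. Compound 2 `Cc1cc(Br)cc(C)c1Oc1ccc([N+](=O)[O-])c(Nc2ccc(C#N)cc2)c1` in this assay gives only a limit, > 57000 nM. Compound 3 `Cc1cccc(C)c1Oc1cc(Nc2ccc(C#N)cc2)c([N+](=O)[O-])cc1[N+](=O)[O-]` in this assay likewise gives only a limit, > 61800 nM.

Compound 2 carries, relative to compound 1, the change (bromo in place of hydrogen on an aromatic carbon). The step that the limit leaves unreadable from compound 1 to compound 2 cannot be sized because of the limit of > 57000 nM in this assay, at which 1 of the 3 values shown sits. The core of compound 3 differs from that of compound 1 by nitro in place of hydrogen on an aromatic carbon, and the step that the limit leaves unreadable from compound 1 to compound 3 is unreadable because of the limit of > 61800 nM in this assay, at which 1 of the 3 values shown sits. Compound 4 `Cc1cc(Br)cc(C)c1Oc1cc(Nc2ccc(C#N)cc2)c([N+](=O)[O-])cc1[N+](=O)[O-]` has not yet been measured; on the core of compound 3 it carries the change (bromo in place of hydrogen on an aromatic carbon), the same change that leads from compound 1 to compound 2, at a place described in the same words. Because the step that the limit leaves unreadable from compound 1 to compound 2 gave no readable size, compound 4 is expected to make a step of an at least 1.0-fold lower number from compound 3 to compound 4 (0.01 log units; that floor lies within the scatter) in this assay that stays at or near the limit. Compound 4 is therefore estimated at 60000 nM, between 30000 nM and 120000 nM, and most likely again reported only as a limit.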

Compound 4, half-maximal cytotoxic concentration: > 51700 nM
Compound 4 gave a limit, no number (the forecaster's own chance of this, stated with the estimate: 80%); the middle value lies beyond the limit too.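

Going by these compounds alone, compound 4, like compound 2 and compound 3, is reported in this assay only as a limit and not as a number, so neither the step from compound 3 to compound 4 nor the one from compound 2 to compound 4 can be read. The compounds shown leave open whether bromo or nitro in place of hydrogen changes the half-maximal cytotoxic concentration at all, and in which direction.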